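Branching a Side Chain: What Compound 3 Might Show

This account rests on a few compounds, and the source may have more. Where it says the series, first, only, none or still open, it means among the compounds named here.

Measured so far:
Compound 1 `CC(C)(C)CCOc1cccc(O)c1C(=O)/C=C/c1ccc(O)cc1`: 3000 nM
Compound 2 `CCCCOc1cccc(O)c1C(=O)/C=C/c1ccc(O)cc1`: > 30000 nM

Both were tested in an assay on THP-1 cells for inhibition of nuclear factor NF-kappa-B complex (Homo sapiens), with stated times of 2 h and 16 h; on this read-out higher numbers stand for weaker inhibition and lower numbers for stronger inhibition. For compound 2 this assay gives only a limit, > 30000 nM, not a number. Compound 2 therefore stands at the weak end of the two results shown, because the step of an at least 10-fold higher number from compound 1 to compound 2 (1.00 log units; beyond the scatter) is beyond the scatter and the limit of > 30000 nM in this assay, at which 1 of the 2 values shown sits, marks where compound 2 sits.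

Compound 3 `CCC(CC)COc1cccc(O)c1C(=O)/C=C/c1ccc(O)cc1` differs from compound 2 by ethyl in place of hydrogen on a saturated chain carbon bound to two saturated chain carbons. For the measured compounds named here, the one measured step that bears on this is an at least 10-fold higher number from compound 1 to compound 2 (1.00 log units; beyond the scatter), in which the chain lost carbon atoms and inhibition fell at least modestly. The step to compound 3 adds carbon atoms back, though at a different position on the chain and in a different shape, so the direction is expected to reverse, with inhibition recovering partly toward compound 1. Since compound 2 has only a limit, the size of the expected step of an at least 3.7-fold lower number from compound 2 to compound 3 (0.57 log units; beyond the scatter) is uncertain. Compound 3 is estimated at 8000 nM, within 2500 nM to 30000 nM.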

Compound 3, half-maximal inhibitory concentration: 12000 nM
Beside the measured number, compound 3's estimate is 1.5-fold (0.18 log units) below it; the measured number falls inside the stated range.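

In this assay, putting ethyl in place of hydrogen on the saturated chain carbon bound to two saturated chain carbons turns butoxy into 2-ethylbutoxy and gives an at least 2.5-fold lower number from compound 2 to compound 3 (0.39 log units; beyond the scatter), so a branch at this place on the chain brings the inhibition back into a range that can be read as a number. On these data alone, the true size of that step stays unknown, because compound 2 has a limit and not a number: the limit of > 30000 nM in this assay, at which 1 of the 3 values shown sits. Branching alone does not settle the outcome, since pentan-3-yl in place of neopentyl gives a 4.0-fold higher number from compound 1 to compound 3 (0.60 log units; beyond the scatter), which shows that two branched chains on the same core are not interchangeable.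

The compounds shown leave open how a longer unbranched chain, such as hexyl, or a chain ending in a cyclohexyl ring would compare with these branched ones. They also leave open whether an amine or a carboxylic acid at the end of the chain would keep, lose or improve the inhibition seen in this assay.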